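This account rests on a few compounds, and the source may have more. Where it says the series, first, only, none or still open, it means among the compounds named here.

Compound 1 `COc1cccc(C(=O)NCc2c(C)cc(C)[nH]c2=O)c1F`: > 150000 nM
Compound 2 `COc1cccc(C(=O)NCc2c(C)cc(C)[nH]c2=O)c1`: > 150000 nM

Both compounds were tested in an assay on Sf9 cells for inhibition of histone-lysine N-methyltransferase EZH2 (Homo sapiens), read by scintillation counting, with a stated time of 60 min, in the presence of a further agent that is not named here; on this read-out lower numbers stand for stronger inhibition and higher numbers for weaker inhibition. For compound 1 the result > 150000 nM is a limit of the assay, not a number. For compound 2 the result > 150000 nM is likewise a limit. Among the measured compounds shown here, compound 2 therefore stands at the limit itself, and the step that the two limits leave unreadable from compound 1 to compound 2 cannot be read as a size; the only evidence in hand is the limit of > 150000 nM in this assay, at which 2 of the 2 values shown sit. Compound 3 `COc1cccc(C(=O)NCc2c(C)cc(C)[nH]c2=O)c1OC` differs from compound 2 by methoxy in place of hydrogen on an aromatic carbon. For the measured compounds named here, no measured step bears directly on this change, and the single step that is known was itself not readable. With both measured neighbours sitting at the limit, the account expects compound 3 to sit there as well, with no step beyond the scatter, so the estimated step of a number no higher from compound 2 to compound 3 (the limit leaves the size open) is close to none. Compound 3 is therefore expected to show about 150000 nM in this assay, within 40000 nM to 600000 nM, and most likely once again only a limit rather than a number.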

Compound 3, half-maximal inhibitory concentration in the histone-lysine N-methyltransferase EZH2 assay: > 140000 nM
Compound 3: no number, only a limit (the forecaster's own chance of this, stated with the estimate: 85%); the middle value does not contradict the limit.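

In the histone-lysine N-methyltransferase EZH2 assay compound 3 gives > 140000 nM and this is a limit of the assay, not a number. The steps to compound 3 from compound 1 and compound 2 therefore cannot be read. The compounds shown leave open how strongly each of the three inhibits, and whether methoxy in place of hydrogen or fluoro changes that at all. In a physicochemical assay for lipophilicity, at pH 7.4 (a higher number here means a more lipophilic compound, a lower number a more polar compound), compound 2 gives 1.7 and compound 3 gives 1.7 as measured numbers.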